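A few compounds are considered here, and "the series" means these few. Any claim that something is new, unique, unknown or untested is made for them only; others in the source may bear on it.

Measured so far:
compound 1 `O=C(Nc1ccc(Cl)cc1)C(=O)N1CC[C@H](c2ccnc3ccc(F)cc23)[C@@H](O)C1` with 6.1 nM in an assay on SK-OV-3 cells for inhibition of Indoleamine 2,3-dioxygenase 1 (Homo sapiens); a lower number here means a stronger inhibitor, a higher number a weaker inhibitor
compound 2 `O=C(Nc1ccc(Cl)cc1)C(=O)N1CC[C@@H](c2ccnc3ccc(F)cc23)[C@H](O)C1` with 50 nM in this assay

Among the compounds with values here, compound 2 gives the higher of the two numbers so far, and its nearest neighbour is compound 1, which lies an 8.2-fold higher number from compound 1 to compound 2 (0.91 log units; beyond the scatter) apart from it. The two are mirror images, and that inversion alone moves the number by a modest but real margin, so the arrangement in space at the ring clearly matters for this pair (the fact that compounds 1 and 2 differ only in the configuration as drawn).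

Compound 3 `O=C(Nc1ccc(Cl)cc1)C(=O)N1CC[C@H](c2ccnc3ccc(F)cc23)[C@H](O)C1` is the next step from compound 2: the two compounds have the same atoms and bonds and differ only in configuration as drawn: 1 of 2 stereo elements differ; a stereocentre at a saturated ring carbon is drawn S in compound 2 and R in compound 3. Only one of the two stereocentres is inverted, so compound 3 is not a mirror image of either measured compound but a distinct spatial form of the same atoms and bonds. Within the data shown here, the only guide is the mirror-image step from compound 1 to compound 2, which was of modest size; a single inversion may move the number by a comparable amount, in either direction. The expected step is a 1.7-fold lower number from compound 2 to compound 3 (0.22 log units; within the scatter). Compound 3 is therefore estimated at 30 nM, with a likely range from 5 nM to 200 nM.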

Compound 3, half-maximal inhibitory concentration: 110 nM
For compound 3 the middle estimate is 3.7-fold (0.56 log units) below the measured one; measured number inside the range.
By their numbers in this assay, from the lowest: compound 1; then compound 2; then compound 3.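

Inverting a single stereocentre is enough to change the number, and by a wide margin: the change gives an 18-fold higher number from compound 1 to compound 3 (1.26 log units; beyond the scatter) and leaves compound 1 the strongest of the three in this assay. Inverting the other stereocentre gives a 2.2-fold higher number from compound 2 to compound 3 (0.34 log units; beyond the scatter) and makes compound 3 the weakest, so each of the two ring stereocentres counts by itself and the effect is not confined to the mirror-image pair. Since the atoms and bonds stay the same, these gaps can come only from the arrangement in space: the fact that compounds 1 and 3 differ only in the configuration as drawn

The mirror image of compound 3 would complete the set of four spatial forms, and its number remains an open question, as does whether the preference for the arrangement in compound 1 would hold in a second assay. From the compounds shown here alone, it also remains open whether that preference depends on the hydroxyl group itself, since a methoxy group or an amine in its place could show whether the same spatial arrangement still gives the lowest number.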